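A few compounds are considered here, and "the series" means these few. Any claim that something is new, unique, unknown or untested is made for them only; others in the source may bear on it.

Measured so far in this series:
compound 1 `CC(C)COC(=O)Nc1ccc([Se]C#N)cc1` — 47300 nM
compound 2 `N#C[Se]c1ccc(NC(=O)Oc2ccc(Cl)cc2)cc1` — 18700 nM

In a functional assay on PC-3 cells (Homo sapiens) for cytotoxicity, read by MTT assay, with a stated time of 72 h (a higher number here means a weaker inhibitor of growth, a lower number a stronger inhibitor of growth), compound 1 gives 47300 nM, the highest of the two numbers measured; its nearest neighbour is compound 2, which in this assay gives 18700 nM, a lower number, and the gap between the two lies beyond the usual scatter. Going by the values given here, no single-point step between measured compounds is available, so any expectation for a new member rests on these two values alone.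

Compound 3 `N#C[Se]c1ccc(NC(=O)OCc2ccccc2)cc1` has not yet been measured in this assay. Relative to compound 1 the change is phenyl in place of isopropyl on a saturated chain carbon bound to an oxygen next to a carbonyl group. The shared core of compound 1 is untouched.

For compound 3 the expected step is a 1.8-fold lower number from compound 1 to compound 3 (0.26 log units; within the scatter), a downward move that is estimated to exceed the scatter, because compound 2, which carries a six-membered aromatic ring of carbon only in its carbamate part, gives 18700 nM in this assay. The estimate for compound 3 in this assay is 26000 nM, with a range of 11000 nM to 60000 nM.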

Compound 3, concentration for total growth inhibition: 27800 nM
Beside the measured number, compound 3's estimate is 1.1-fold (0.03 log units) below it; measured number inside the range.
By their numbers in this assay, from the lowest: compounds 2, 3 and 1 (each within the scatter of the next, the first and the last beyond it).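

Working from this assay, the series now has its first single-point step, a 1.7-fold lower number from compound 1 to compound 3 (0.23 log units; within the scatter), for phenyl in place of isopropyl on a saturated chain carbon bound to an oxygen next to a carbonyl group. Going by these compounds alone, at this place, therefore, going from isopropyl, with 3 heavy atoms and no ring, to phenyl, with 6 heavy atoms and one six-membered aromatic ring of carbon only, leaves the two compounds within the scatter of each other, a reading that the earlier pair, with no single-point step between them, could not give. Nothing available explains this outcome or ties it to any property of either group.

Still open, on these data alone, is whether an amine, a carboxylic acid or a longer chain in the same place, on a saturated chain carbon bound to an oxygen next to a carbonyl group, would give a step beyond the scatter from compound 1 or compound 3. A single step within the scatter supports no general rule for this place, so the reading holds only for the isopropyl and phenyl pair.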